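A few compounds are considered here, and "the series" means these few. Any claim that something is new, unique, unknown or untested is made for them only; others in the source may bear on it.

Measured in a functional assay on the whole organism with Rattus norvegicus as the target, at a dose of 100 mg/kg; a lower number here means less inhibition, a higher number more inhibition at the dose given (going by the name of the read-out):

Compound 1, `CC/N=C(\S)NCCCCCCn1nc(-c2ccccc2)ccc1=O`: compound 1 gives -5.6%.
Compound 2, `CC(C)(C)/N=C(\S)NCCCCn1nc(-c2ccccc2)ccc1=O`: compound 2 gives 33.6%.
Compound 3, `N/C(S)=N/CCCCn1nc(-c2ccccc2)ccc1=O`: compound 3 gives 72%.

All three share the same core and a thiourea-bearing chain; they differ only in what sits on the thiourea and in the length of the chain. Compound 1 stands lowest of the three, with its two neighbours both clearly above it: a number 39.2 percentage points higher from compound 1 to compound 2 (beyond the scatter) and a number 77.6 percentage points higher from compound 1 to compound 3 (beyond the scatter). Between the other two, a number 38.4 percentage points higher from compound 2 to compound 3 (beyond the scatter).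

Compound 4, `CC/N=C(/NC#N)NCCCCCn1nc(-c2ccccc2)ccc1=O`, has not yet been measured in this assay. Compared with compound 1 it carries a group of 8 heavy atoms (4 carbon, 4 nitrogen; no ring) in place of a group of 7 heavy atoms (4 carbon, 2 nitrogen, 1 sulfur; no ring), on a saturated chain carbon, five bonds along the chain from an aromatic nitrogen. Going by the values given here, no measured step swaps the sulfur of the thiourea for a cyanoimine, nor shortens the chain by one link, so the change is only loosely related to what has been seen. What the measured steps do show is that every change made to compound 1 so far has pushed the number up, by large amounts in both cases, and compound 1 sits at the floor of the set. A step upward of moderate size is therefore expected, with wide uncertainty: compound 4 is estimated at 25%, in a range from -10% to 60%, which would mean an expected step of a number 30.6 percentage points higher from compound 1 to compound 4 (beyond the scatter).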

Compound 4, a percentage reported as inhibition, in the whole organism at one dose (the size of the read-out at that dose, not a potency): 48.2%
Estimate against measurement, compound 4: 23.2 percentage points below; measured number inside the range.
By their numbers in this assay, from the lowest: compound 1; then compound 2; then compound 4; then compound 3.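

In this assay the swap on the saturated chain carbon, five bonds along the chain from an aromatic nitrogen, brings in a group of 8 heavy atoms (4 carbon, 4 nitrogen) for a group of 7 heavy atoms (4 carbon, 2 nitrogen, 1 sulfur), and it gives a number 53.8 percentage points higher from compound 1 to compound 4 (beyond the scatter). This is the first step shown in which the sulfur leaves altogether, so among these compounds a number well above that of compound 1 does not depend on keeping sulfur at this position, and a nitrile-bearing group, with its triple bond and second hydrogen-bond acceptor, is compatible with such a rise. Nothing shown explains the size of this step or tells which part of the swap accounts for it.

Going by these compounds, since the chain and its end group change together in this one step, the share of each stays open, and a direct answer would need the nitrile-bearing group on the longer chain of compound 1 or on a shorter one. Also open, on these data alone, is how a urea, with oxygen where the sulfur stands, or a plain amine at the end of the chain would compare with compound 4.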